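Bromine position on the benzyl group of compound 1

The source may report more compounds than this note shows. Statements on the series, on what has been measured and on what is new or still open speak of the compounds shown alone.

Compound 1, `CCN(Cc1cccc(Br)c1)c1ccc(C(=O)N2CCc3ccc(OS(N)(=O)=O)cc3C2)cc1`, carries an ethyl group and a 3-bromobenzyl group on the nitrogen attached to the aromatic ring that links to the shared core. In an assay on HEK293 cells for inhibition of Steryl-sulfatase (Homo sapiens), tested at 0.1 uM (a higher number here means a stronger effect of the compound at the concentration tested, a lower number a weaker effect), compound 1 gives 80.2%, the highest of the three numbers measured. Compound 2, `NS(=O)(=O)Oc1ccc2c(c1)CN(C(=O)c1cccc(N3CCN(c4ncccn4)CC3)c1)CC2`, gives 1.6%, and compound 3, `CCN(Cc1ccccc1)Cc1ccc(S(=O)(=O)N2CCc3ccc(OS(N)(=O)=O)cc3C2)cc1`, gives 10%; both stand far below compound 1, beyond the scatter. None of these three pairs differs in a single place, so no single step can be read from the measured set.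

Compound 4, `CCN(Cc1ccc(Br)cc1)c1ccc(C(=O)N2CCc3ccc(OS(N)(=O)=O)cc3C2)cc1`, differs from compound 1 in one place: 4-bromophenyl in place of 3-bromophenyl on a saturated chain carbon bound to a nitrogen on an aromatic ring. The ethyl group, the amide link and the shared core are unchanged. Shifting the bromine within the same benzyl ring is expected to leave the read-out close to that of compound 1, so the step of a number 8.2 percentage points lower from compound 1 to compound 4 (within the scatter) is estimated to be small, slightly downward, and probably within the scatter. Compound 4 is accordingly expected to give 72%, with a range from 45% to 90%.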

Compound 4, a percentage reported as inhibition, at one concentration (the size of the read-out at that concentration, not a potency): 78.2%
Compound 4: middle estimate off by 6.2 percentage points, on the low side; the measured number falls inside the stated range.
By their numbers in this assay, from the lowest: compounds 2 and 3 (each within the scatter of the next); then compounds 4 and 1 (each within the scatter of the next).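

Moving the bromine is the first change in the series that can be read in a single place: in this assay, 4-bromophenyl in place of 3-bromophenyl on a saturated chain carbon bound to a nitrogen on an aromatic ring gives a number 2 percentage points lower from compound 1 to compound 4 (within the scatter), so the read-out does not separate these two groups. Both bromobenzyl compounds therefore carry the number seen for compound 1, and the bromine location on this ring does not decide the result at the single concentration tested. No evidence on hand bears on this result.

Whether the bromine itself contributes stays open, as the compounds shown include no direct counterpart with an unsubstituted phenyl, or with chlorine or a methoxy group in its place. A longer chain such as propyl in place of the ethyl group on the same nitrogen also remains an open comparison.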